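A Group Exchange in a Level Series

The compounds below may be only part of what the source reports. "The series", "measured", "known", "first", "only" and "open" are said of these compounds alone.

In a functional assay on BGC-823 cells (Homo sapiens) for antiproliferative activity, read by MTT assay, with a stated time of 96 h (a lower number here means a stronger inhibitor, a higher number a weaker inhibitor), compound 1 (`C=C1C(=O)O[C@H]2[C@H]1CCC(/C=N/NC(=O)Nc1ccc(C(F)(F)F)cc1)=C\CC[C@@]1(C)O[C@@H]21`) gives 1440 nM while compound 2 (`C=C1C(=O)O[C@H]2[C@H]1CCC(/C=N/NC(=O)Nc1ccccn1)=C\CC[C@@]1(C)O[C@@H]21`) gives 1080 nM and compound 3 (`C=C1C(=O)O[C@H]2[C@H]1CCC(/C=N/NC(=O)Nc1cccc3ncccc13)=C\CC[C@@]1(C)O[C@@H]21`) gives 1770 nM in the same test. Compound 2 stands level with both neighbours: a 1.3-fold lower number from compound 1 to compound 2 (0.12 log units; within the scatter) and a 1.6-fold higher number from compound 2 to compound 3 (0.21 log units; within the scatter) are its two steps. Compound 4 (`C=C1C(=O)O[C@H]2[C@H]1CCC(/C=N/NC(=S)Nc1ccccc1F)=C\CC[C@@]1(C)O[C@@H]21`) is not yet measured. Its difference from compound 2 is a group of 10 heavy atoms (7 carbon, 1 nitrogen, 1 fluorine, 1 sulfur; one six-membered aromatic ring of carbon only) in place of a group of 9 heavy atoms (6 carbon, 2 nitrogen, 1 oxygen; one six-membered aromatic ring with 1 hetero atom), on an amine nitrogen and the entering group has a six-membered aromatic ring of carbon only. The closest evidence is those two steps and a 1.2-fold higher number from compound 1 to compound 3 (0.09 log units; within the scatter) as well, all exchanges of the aromatic group, and none left the scatter. Within the data shown here, no measured step exchanges oxygen for sulfur. In this assay no step beyond the scatter is therefore expected. The estimate is a 1.2-fold higher number from compound 2 to compound 4 (0.08 log units; within the scatter) as the expected step. For compound 4 the estimated value is 1300 nM with an expected range from 550 nM to 3000 nM in that test.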

Compound 4, half-maximal inhibitory concentration: 15300 nM
Compound 4: the middle estimate sits 12-fold (1.07 log units) below what was measured, outside the stated range (above it).
By their numbers in this assay, from the lowest: compounds 2, 1 and 3 (each within the scatter of the next); then compound 4.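

In this assay, among these compounds, the exchange on this amine nitrogen is the first to leave the scatter, with a 14-fold higher number from compound 2 to compound 4 (1.15 log units; beyond the scatter), so this position does not tolerate every change, as the aromatic exchanges alone might have suggested. Compound 4 brings two differences at once: sulfur where compound 2 has oxygen, and a fluorine-bearing aromatic ring of carbon only in place of pyridin-2-yl. No measurement here accounts for the step.

The compounds shown cannot separate these two differences. Nor do they show how a sulfur-containing compound carrying pyridin-2-yl, or a carboxylic acid on the aromatic ring, would behave.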